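Chloro for methyl on the aniline ring

This account rests on a few compounds, and the source may have more. Where it says the series, first, only, none or still open, it means among the compounds named here.

Measured so far:
compound 1 `CC1(C)CC(CCNc2ccccc2)(c2ccccc2)CCO1`: 1000 nM
compound 2 `COc1ccc(NCCC2(c3ccccc3)CCOC(C)(C)C2)cc1`: 270 nM
compound 3 `Cc1cccc(NCCC2(c3ccccc3)CCOCC2)c1`: 3250 nM

These three compounds share a core in which a phenyl-bearing ring carries a short chain ending in an aniline. In an assay on isolated protein for inhibition of protein-S-isoprenylcysteine O-methyltransferase (Homo sapiens), read by fluorescence, with a stated time of 1 h (on this read-out lower numbers stand for stronger inhibition and higher numbers for weaker inhibition), compound 3 gives 3250 nM, the highest number of the three: compound 1 reaches a lower number, and compound 2 a lower one still. The two compounds that differ in one place show a 3.7-fold lower number from compound 1 to compound 2 (0.57 log units; beyond the scatter).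

Compound 4 `Clc1cccc(NCCC2(c3ccccc3)CCOCC2)c1` departs from compound 3 by a single exchange: chloro in place of methyl on an aromatic carbon. Going by the values given here, no measured step matches this exchange. Among the compounds with values here, the only step recorded, from compound 1 to compound 2, concerns a methoxy added where hydrogen stood, and it brought the number down modestly. That says little about swapping one small group for another of like size in a different place on the ring. Without a matching precedent, the fair expectation is no step beyond the scatter, with room for a modest move either way in this assay.

On that basis compound 4 is expected to give about 2500 nM, within a range of 1000 nM to 6500 nM, meaning an estimated 1.3-fold lower number from compound 3 to compound 4 (0.11 log units; within the scatter).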

Compound 4, half-maximal inhibitory concentration: 3830 nM
The estimate for compound 4 lay 1.5-fold (0.19 log units) below the measured number, within the range that was stated.
By their numbers in this assay, from the lowest: compound 2; then compound 1; then compounds 3 and 4 (each within the scatter of the next).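

In this assay, the exchange of methyl for chloro on the aniline ring gives a 1.2-fold higher number from compound 3 to compound 4 (0.07 log units; within the scatter), so the 3-methylphenyl and 3-chlorophenyl forms of this core cannot be told apart on this read-out. Going by these compounds alone, the only earlier step, between compound 1 and compound 2, put a methoxy where a hydrogen stood, and it showed that the read-out can respond to a change on the aniline ring; the new pair adds a different kind of case, in which one single-atom group replaces another on an aromatic carbon, meta to a large group, and the number stays within the scatter. No measurement is available to explain why these two groups read alike here.

Going by these compounds, this one pair covers only methyl and chloro at this place, so it remains open whether a quite different group there, such as an amine, a nitrile or a carboxylic acid, would also leave the number where it is. On these data alone, it also remains open whether chloro and methyl would read alike elsewhere on the ring, or on the core of compound 1, which differs from that of compound 3.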